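The compounds below may be only part of what the source reports. "The series", "measured", "known", "first", "only" and "open" are said of these compounds alone.

Working notes on the series, on the read-out of a toxicity assay on MDCK cells (Canis lupus familiaris) for cytotoxicity, read by crystal violet staining, with a stated time of 48 h; on this read-out higher numbers stand for lower toxicity in this test and lower numbers for higher toxicity in this test. Compound 1 `CCc1ccc(CN(Cc2ccc(F)cc2)Cc2cc3ccc(C)cc3[nH]c2=O)cc1` gives > 33000 nM, which is a limit of the assay and not a number. Compound 2 `Cc1ccc2cc(CN(Cc3ccc(C(C)(C)C)cc3)Cc3cc(F)cc(F)c3)c(=O)[nH]c2c1` gives > 33000 nM, again a limit. Compound 3 `CCc1ccc2[nH]c(=O)c(CN(Cc3ccc(F)cc3)Cc3ccc(C(C)(C)C)cc3)cc2c1` gives > 33000 nM, also a limit. Among the compounds with values here, compound 2 therefore sits at the limit of > 33000 nM in this assay, at which 3 of the 3 values shown sit, alongside the other two measured compounds, so no step between measured compounds can be counted in this assay. Compound 4 `Cc1ccc2cc(CN(Cc3ccc(C(C)(C)C)cc3)CC3CCCCC3)c(=O)[nH]c2c1` is the one still to be measured; it differs from compound 2 by cyclohexyl in place of 3,5-difluorophenyl on a saturated chain carbon bound to an amine nitrogen. The expected step is a step that the limit leaves unreadable from compound 2 to compound 4, none beyond the scatter. Compound 4 is estimated at 40000 nM, within 20000 nM to 100000 nM.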

Compound 4, half-maximal cytotoxic concentration: > 10000 nM
Compound 4: no number, only a limit (the forecaster's own chance of this, stated with the estimate: 80%); the middle value is on the limit's open side.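

In this assay, within the data shown here, compound 2 and compound 4 both give limits and not numbers, so no step between them can be read. The compounds shown leave open whether cyclohexyl in place of 3,5-difluorophenyl changes the half-maximal cytotoxic concentration at all.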